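The source may hold more compounds than are shown below. What is called first, only, known or untested is meant among the compounds shown, and "the series" means these compounds.

Measured so far in an in vitro assay on BaF3 cells for displacement of a labelled ligand from C-X-C chemokine receptor type 3 (Homo sapiens); a higher number here means a weaker inhibitor, a lower number a stronger inhibitor:
compound 1, `CC[C@H]1CN(c2nc(N)c(C(=O)NCC(C)O)nc2Cl)CCN1C1CCN(Cc2ccc(Cl)cc2)CC1`, gives 0.3 nM
compound 2, `CC[C@H]1CN(c2ncc(C(N)=O)nc2Cl)CCN1C1CCN(C(=O)c2ccc(Cl)nc2N)CC1`, gives 2.5 nM
compound 3, `CC[C@H]1CN(c2ncc(C(N)=O)nc2C(F)(F)F)CCN1C1CCN(C(=O)c2ccc(Cl)nc2N)CC1`, gives 1.9 nM

Compound 3 holds the second highest number of the three in this assay. Its nearest neighbour is compound 2; that step, a 1.3-fold lower number from compound 2 to compound 3 (0.12 log units; within the scatter), lies within the scatter, whereas compound 1 sits beyond it. Compound 4, `CC[C@H]1CN(c2ncc(C(=O)NC)nc2C(F)(F)F)CCN1C1CCN(C(=O)c2ccc(Cl)nc2N)CC1`, differs from compound 3 by methyl in place of hydrogen on an amide-type nitrogen. No measured step touches the amide nitrogen; the one shown step concerns a ring substituent. Compound 1 carries a substituted amide and a lower number, but it differs in several further places and gives no clean guide. Compound 4 is therefore expected to stay close, the expected step being a 1.3-fold higher number from compound 3 to compound 4 (0.12 log units; within the scatter). Compound 4 is estimated at 2.5 nM, between 1 nM and 6 nM.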

Compound 4, half-maximal inhibitory concentration: 1.5 nM
For compound 4 the middle estimate is 1.7-fold (0.22 log units) above the measured one, and the stated range covers the measured number.
By their numbers in this assay, from the lowest: compound 1; then compounds 4, 3 and 2 (each within the scatter of the next).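

In this assay, methyl in place of hydrogen on the amide-type nitrogen gives a 1.3-fold lower number from compound 3 to compound 4 (0.10 log units; within the scatter). This is the first single change shown at this nitrogen, and it shows that the carbamoyl to methylcarbamoyl swap keeps the number within the scatter on this core. The step from compound 2 to compound 3 concerned a different place and could not show this. No measurement shown accounts for this result. As far as these compounds go, it remains open whether an ethyl or cyclopropyl group on this nitrogen, or a second methyl there, would also stay within the scatter.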